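Alkyne-linked aryloxyacetic acids: fluoro for hydroxymethyl

The compounds below may be only part of what the source reports. "The series", "measured", "known", "first", "only" and "open" are said of these compounds alone.

Measured so far:
compound 1, `O=C(O)COc1ccc(Cl)cc1C#Cc1ccc(CO)cc1F`: 28 nM
compound 2, `CS(=O)(=O)Cc1cccc(C#Cc2cc(Cl)ccc2OCC(=O)O)c1`: 48 nM

In an assay on CHO cells for displacement of a labelled ligand from prostaglandin D2 receptor 2 (Homo sapiens), read by scintillation counting (a higher number here means a weaker inhibitor, a lower number a stronger inhibitor), compound 1 gives 28 nM and compound 2 gives 48 nM. Compound 1 carries the lower of the two numbers, but the gap to compound 2 lies within the scatter, so the two cannot be ordered against each other.

Compound 3, `O=C(O)COc1ccc(Cl)cc1C#Cc1ccc(F)cc1F`, is not yet measured. It differs from compound 1 by fluoro in place of hydroxymethyl on an aromatic carbon, on the ring at the far end of the alkyne from the shared core. Among the measured compounds shown here, no pair of measured compounds shows this change, so there is no measured step to lean on, and the two numbers in hand sit close together and give no trend of their own.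

The step of a 1.8-fold higher number from compound 1 to compound 3 (0.25 log units; within the scatter) is expected to be small, tending toward a higher number, and not clearly beyond the scatter. Compound 3 is accordingly estimated at 50 nM, with a range from 15 nM to 170 nM.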

Compound 3, inhibition constant: 101 nM
Estimate against measurement, compound 3: 2.0-fold (0.31 log units) below, within the range that was stated.
By their numbers in this assay, from the lowest: compounds 1 and 2 (each within the scatter of the next); then compound 3.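

In this assay fluoro in place of hydroxymethyl on an aromatic carbon, meta to a fluoro group and para to a large group, gives a 3.6-fold higher number from compound 1 to compound 3 (0.56 log units; beyond the scatter) and this modest step lies beyond the scatter. Among the compounds shown here, as the only measured step, it shows that the position on the ring at the far end of the alkyne is not indifferent to the group it carries: when hydroxymethyl, with its hydrogen-bond donor and acceptor, gives way to fluoro, the number rises. No measurement at hand bears on what lies behind the step, so the pair gives the direction and size of this one exchange and no explanation of it.

This single pair cannot separate the part played by the hydroxyl oxygen from that of the carbon that carries it, and a methyl, methoxy or aminomethyl group at this position would help to tell these apart. As far as these compounds go, whether the step would hold at the same size on a compound with another group on the shared core also remains open.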